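Cytotoxicity of a chalcone series on Vero cells

A few compounds are considered here, and "the series" means these few. Any claim that something is new, unique, unknown or untested is made for them only; others in the source may bear on it.

Compound 1 `COC(=O)c1cc(-c2cccc(NC(=O)c3ccc(/C=C/C(=O)c4ccc(F)cc4)cc3)c2)on1`: > 20 ug/mL in an ADME assay on Vero cells (Chlorocebus sabaeus) for cytotoxicity, read by MTT assay, with a stated time of 72 h (a lower number here means that less compound is tolerated, a higher number that more compound is tolerated), a limit of the assay.
Compound 2 `COC(=O)c1cc(-c2cccc(NC(=O)c3ccc(/C=C/C(=O)c4ccc(Cl)cc4)cc3)c2)on1`: > 50 ug/mL in this assay, a limit of the assay.
Compound 3 `COC(=O)c1cc(-c2cccc(NC(=O)c3ccc(/C=C/C(=O)c4ccc(OC)c(OC)c4)cc3)c2)on1`: > 50 ug/mL in this assay, a limit of the assay.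

All three measured compounds sit at limits in this assay, so none of the steps among them can be read: a step that the two limits leave unreadable from compound 1 to compound 2, a step that the two limits leave unreadable from compound 1 to compound 3 and a step that the two limits leave unreadable from compound 2 to compound 3 are all unreadable in size. Compound 3 stands at the upper of the two limits, shared with compound 2 (the limit of > 50 ug/mL in this assay, at which 2 of the 3 values shown sit), while compound 1 sits at the lower one (the limit of > 20 ug/mL in this assay, at which 1 of the 3 values shown sits).

Compound 4 `COC(=O)c1cc(-c2cccc(NC(=O)c3ccc(/C=C/C(=O)c4ccc([N+](=O)[O-])cc4)cc3)c2)on1` differs from compound 3 by the change (4-nitrophenyl in place of 3,4-dimethoxyphenyl on a carbonyl carbon). Among the measured compounds shown here, no measured step bears on this change in a readable way; the only information is that the three values shown are all limits and that changing the aryl group on the carbonyl carbon has not yet produced a measurable number. The step from compound 3 to compound 4 in this assay is therefore expected to be a number no higher from compound 3 to compound 4 (the limit leaves the size open), none beyond the scatter. Compound 4 is estimated to give 50 ug/mL, within 20 ug/mL to 120 ug/mL, most likely again reported only as a limit.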

Compound 4, half-maximal cytotoxic concentration: > 20 ug/mL
Compound 4 ended at the assay's limit; the forecaster's own chance of this, stated with the estimate: 75%; the middle value lies beyond the limit too.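

Compound 4, like compound 1, compound 2 and compound 3, is reported only as a limit in this assay, so none of its steps to those three compounds can be read. With all four values limits, the compounds shown leave open whether changing the aryl group on the carbonyl carbon alters the half-maximal cytotoxic concentration at all.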